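A few compounds are considered here, and "the series" means these few. Any claim that something is new, unique, unknown or untested is made for them only; others in the source may bear on it.

Working notes on an octadecyl-amide series. The shared core carries an aryl group on a saturated ring carbon, and three variants have been measured in a functional assay on PPC-1 cells (Homo sapiens) for antiproliferative activity, read by sulforhodamine B assay; a lower number here means a stronger inhibitor, a higher number a weaker inhibitor. Compound 1 `CCCCCCCCCCCCCCCCCCNC(=O)[C@H]1CSC(c2cccc(O)c2)N1` gives 1200 nM. Compound 2 `CCCCCCCCCCCCCCCCCCNC(=O)[C@H]1CSC(c2ccc([N+](=O)[O-])cc2)N1` gives 15300 nM. Compound 3 `CCCCCCCCCCCCCCCCCCNC(=O)[C@H]1CSC(c2ccc(C#N)cc2)N1` gives 5000 nM. On these numbers compound 3 stands second highest of the three: the step of a 4.2-fold higher number from compound 1 to compound 3 (0.62 log units; beyond the scatter) is modest, and the step of a 3.1-fold lower number from compound 2 to compound 3 (0.49 log units; beyond the scatter) is modest as well, while the step of a 13-fold higher number from compound 1 to compound 2 (1.11 log units; beyond the scatter) is the largest seen.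

Compound 4 `CCCCCCCCCCCCCCCCCCNC(=O)[C@H]1CSC(c2c(Cl)cccc2Cl)N1` is not yet measured. The change is 2,6-dichlorophenyl in place of 4-cyanophenyl on a saturated ring carbon. The three measured steps all swap the substituent on this aryl ring, so all three bear on it, but none of them involves a dichloro pattern, and the entering group carries no hydrogen-bond donor or acceptor, unlike the hydroxyl of compound 1, the nitro of compound 2 and the cyano of compound 3. The measured swaps moved the number by modest to large amounts, so a step beyond the scatter in this assay is plausible, with direction uncertain.

For compound 4 the expected step is a 1.4-fold lower number from compound 3 to compound 4 (0.15 log units; within the scatter). The estimate for compound 4 is 3500 nM, with a range from 1000 nM to 12000 nM.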

Compound 4, half-maximal inhibitory concentration: 17100 nM
For compound 4 the middle estimate is 4.9-fold (0.69 log units) below the measured one, and the stated range ends below it.
By their numbers in this assay, from the lowest: compound 1; then compound 3; then compounds 2 and 4 (each within the scatter of the next).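

In this assay, replacing 4-cyanophenyl with 2,6-dichlorophenyl on the saturated ring carbon gives a 3.4-fold higher number from compound 3 to compound 4 (0.53 log units; beyond the scatter), so this position responds to a swap between two aryl groups of equal heavy-atom count, one with a hydrogen-bond acceptor and one with none. The step of a 1.1-fold higher number from compound 2 to compound 4 (0.05 log units; within the scatter) places the 2,6-dichlorophenyl and 4-nitrophenyl groups level, showing that two quite different substitutions can give the same result here, while a 14-fold higher number from compound 1 to compound 4 (1.15 log units; beyond the scatter) leaves compound 1, with its 3-hydroxyphenyl group, holding the lowest number of the four in this assay. No measured data are available to explain any of these differences at this position.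

The compounds shown leave open whether the lower number of compound 1 belongs to the hydroxyl itself, since a single hydroxyl compound cannot separate that group from its place on the aryl ring. From the compounds shown here alone, how an unsubstituted phenyl, an aminophenyl or a carboxyphenyl group would compare at this carbon also remains open, as does whether the same order would hold with a dodecyl chain in place of the octadecyl chain.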